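Moving chlorine on the benzyl ether of compound 2

The source may report more compounds than this note shows. Statements on the series, on what has been measured and on what is new or still open speak of the compounds shown alone.

In an ADME assay on cells (Astrocyte, Homo sapiens) for cytotoxicity, read by WST assay, with a stated time of 72 h (on this read-out higher numbers stand for weaker inhibition and lower numbers for stronger inhibition), compound 1 (`O=C(Nc1ccc(C(F)(F)F)cc1)Nc1cc2ncncc2cc1OCc1cccc(F)c1`) gives 8900 nM as a measured number. Compound 2 (`O=C(Nc1cc2ncncc2cc1OCc1ccc(Cl)cc1)Nc1cccc2ccccc12`) reads > 10000 nM here, which is a limit and not a number. Compound 3 (`O=C(Nc1cccc(F)c1)Nc1cc2ncncc2cc1OCc1cccc(Cl)c1`) reads > 10000 nM here, again a limit only. The picture so far is dominated by the limit of > 10000 nM in this assay, at which 2 of the 3 values shown sit, and no two of these compounds differ in one place only.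

Compound 4 (`O=C(Nc1cc2ncncc2cc1OCc1ccccc1Cl)Nc1cccc2ccccc12`) has the same atoms as compound 2, joined differently: 2-chlorophenyl stands in place of 4-chlorophenyl on a saturated chain carbon bound to an oxygen on an aromatic ring (2-chlorophenyl in place of 4-chlorophenyl on a saturated chain carbon bound to an oxygen on an aromatic ring).

Among the compounds with values here, no measured step shows what such a change does in this assay, and no shift beyond the usual scatter is expected in either direction. The expectation starts from compound 2 with its > 10000 nM reading, which is a limit. The estimated step that the limit leaves unreadable from compound 2 to compound 4 is therefore expected to stay within the scatter, and compound 4 may well report only a limit too. Compound 4 is expected at 12000 nM in this assay, with an estimated range from 6000 nM to 20000 nM if a number is returned.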

Compound 4, half-maximal inhibitory concentration: 2300 nM
Beside the measured number, compound 4's estimate is 5.2-fold (0.72 log units) above it; the whole stated range lies above it.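

The series now holds its first comparison in one place, and in this assay 2-chlorophenyl in place of 4-chlorophenyl on a saturated chain carbon bound to an oxygen on an aromatic ring gives an at least 4.3-fold lower number from compound 2 to compound 4 (0.63 log units; beyond the scatter). With the atoms unchanged, where the chlorine sits on the benzyl ether is therefore enough on its own to bring a measured number out of a reading that was only a limit, so this position is not silent in this read-out. The true size of the step stays open-ended because one end of it is a limit rather than a number: the limit of > 10000 nM in this assay, at which 2 of the 4 values shown sit.

As far as these compounds go, whether the same move of chlorine lowers the number with other groups on the urea remains open, since compound 1 and compound 3 each differ from compound 4 in more than one place and give no reading of it. Also open, from the compounds shown here alone, is how far this position tolerates change in this assay, for example a carboxylic acid or an amine in place of the chlorine on the benzyl ring.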